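The compounds below may be only part of what the source reports. "The series", "measured", "known", "first", "only" and "open" are said of these compounds alone.

Among the compounds with values here, compound 2 `COc1ccc(OCC(=O)Nc2cccc(NC(=O)c3ccc(N(C)C)cc3)c2)cc1F` is the only compound in this set with a numerical result: in an assay on isolated protein for inhibition of Rho-associated protein kinase 1 (Homo sapiens), read by scintillation counting, radiometric assay and 33P incorporation, with a stated time of 40 min, in the presence of a further agent that is not named here (a lower number here means a stronger inhibitor, a higher number a weaker inhibitor), compound 2 gives 1820 nM. Compound 1 `COc1cccc(OCC(=O)Nc2cccc(NC(=O)c3ccc(N(C)C)cc3)c2)c1` differs from it only in the ring attached to the oxygen on a saturated carbon, and in this assay compound 1 reaches only a limit of the assay, > 10000 nM (the limit of > 10000 nM in this assay, at which 1 of the 2 values shown sits). Within the data shown here, that single step, an at least 5.4-fold lower number from compound 1 to compound 2 (0.73 log units; beyond the scatter), is the only measured guide to what this ring tolerates. Compound 3 `CN(C)c1ccc(C(=O)Nc2cccc(NC(=O)COc3ccc4c(c3)OCCO4)c2)cc1` alters the same ring again: 2,3-dihydro-1,4-benzodioxin-6-yl in place of 3-fluoro-4-methoxyphenyl on an oxygen on a saturated carbon. Among the measured compounds shown here, both the leaving and the entering ring carry oxygen on the aromatic ring, and no measured step other than an at least 5.4-fold lower number from compound 1 to compound 2 (0.73 log units; beyond the scatter) gives any hint of direction for such a swap, so compound 3 is expected to land close to compound 2, with no shift beyond the scatter assumed. For compound 3 the estimate in this assay is 2000 nM, with a range from 600 nM to 7000 nM, corresponding to an expected step of a 1.1-fold higher number from compound 2 to compound 3 (0.04 log units; within the scatter).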

Compound 3, half-maximal inhibitory concentration: > 10000 nM
Compound 3: a limit, no number; the forecaster's own chance of this, stated with the estimate: 15%; at least 5.0-fold (0.69 log units) between middle value and limit.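

In this assay, the ring on the oxygen on a saturated carbon proves demanding: replacing 3-fluoro-4-methoxyphenyl with 2,3-dihydro-1,4-benzodioxin-6-yl gives an at least 5.4-fold higher number from compound 2 to compound 3 (0.73 log units; beyond the scatter). Oxygen on the aromatic ring is therefore not enough on its own to give a numerical result, since compound 3 carries it and still reaches only a limit of the assay, > 10000 nM. Of the three rings shown, only the one in compound 2 gives a number, and the step between compound 1 and compound 3 cannot be read, as both are limits: the limit of > 10000 nM in this assay, at which 2 of the 3 values shown sit.

The compounds shown do not separate the part played by the fluorine in compound 2 from that of its methoxy group. On these data alone, how a ring carrying chlorine or an amine would read in this assay also stays open.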